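Compound 3: isopropoxy in place of the aminophenyl of compound 2

The source may report more compounds than this note shows. Statements on the series, on what has been measured and on what is new or still open speak of the compounds shown alone.

Among the compounds with values here, compound 2 `CC(C)(C)n1cc2c(n1)C(=O)CC1(CCN(C(=O)c3cc(-c4ccc(N)cc4)nc4ccccc34)CC1)O2` gives 4960 nM in a functional assay on MDA-MB-231 cells (Homo sapiens) for inhibition, read by MTT assay, with a stated time of 72 h (on this read-out lower numbers stand for stronger inhibition and higher numbers for weaker inhibition), the only number in the set. Compound 1 `COc1ccc(-c2cc(C(=O)N3CCC4(CC3)CC(=O)c3nn(C(C)(C)C)cc3O4)c3ccccc3n2)cc1` shows > 10000 nM in this assay, a limit rather than a number (the limit of > 10000 nM in this assay, at which 1 of the 2 values shown sits). Within the data shown here, the single measured step is an at least 2.0-fold lower number from compound 1 to compound 2 (0.30 log units; that floor lies within the scatter). Compound 3 `CC(C)Oc1cc(C(=O)N2CCC3(CC2)CC(=O)c2nn(C(C)(C)C)cc2O3)c2ccccc2n1` differs from compound 2 by isopropoxy in place of 4-aminophenyl on an aromatic carbon. That measured step touches the same 4-aminophenyl but only exchanges amino for methoxy, so it offers no direct guide to replacing the whole group with isopropoxy. Among the measured compounds shown here, with no closer precedent, compound 3 is expected to give 8000 nM (range 2500 nM to 25000 nM), a step of a 1.6-fold higher number from compound 2 to compound 3 (0.21 log units; within the scatter).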

Compound 3, half-maximal inhibitory concentration: > 10000 nM
Compound 3 ended at the assay's limit; the forecaster's own chance of this, stated with the estimate: 40%; middle value at least 1.2-fold (0.09 log units) from the limit.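

Isopropoxy in place of 4-aminophenyl, next to the ring nitrogen, gives an at least 2.0-fold higher number from compound 2 to compound 3 (0.30 log units; that floor lies within the scatter), so this position now carries a substituent with no ring, and the floor of that step does not go beyond the scatter. The step from compound 1 to compound 3 cannot be read, as both ends are limits and not numbers: the limit of > 10000 nM in this assay, at which 2 of the 3 values shown sit.

From the compounds shown here alone, how a piperazine or a 3-aminophenyl at this position would compare with compound 2 in this assay stays open. Going by these compounds, the true size of the loss on leaving 4-aminophenyl also stays open.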